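Chain in Place of Branched Group on the Amide

The source may report more compounds than this note shows. Statements on the series, on what has been measured and on what is new or still open speak of the compounds shown alone.

Two sulfonate esters have been measured. Compound 1 `CC(=O)Nc1ccc(S(=O)(=O)Oc2ccccc2C(C)C)cc1` gives 21000 nM in a functional assay on M21 cells (Homo sapiens) for antiproliferative activity, read by sulforhodamine B assay, with a stated time of 48 h; a higher number here means a weaker inhibitor, a lower number a stronger inhibitor. Compound 2 `CC(C)c1ccccc1OS(=O)(=O)c1ccc(NC(=O)C(C)(C)C)cc1` gives 6200 nM in this assay, which is the lowest of the two numbers, its nearest neighbour being compound 1. Among the measured compounds shown here, the single step, a 3.4-fold lower number from compound 1 to compound 2 (0.53 log units; beyond the scatter), is a modest change that came from tert-butyl in place of methyl on a carbonyl carbon.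

Compound 3 `CC(C)c1ccccc1OS(=O)(=O)c1ccc(NC(=O)CCCCl)cc1` has not been measured. It differs from compound 2 by 3-chloropropyl in place of tert-butyl on a carbonyl carbon. For the measured compounds named here, no measured step tells what a chain of this kind does here; the one step known, a 3.4-fold lower number from compound 1 to compound 2 (0.53 log units; beyond the scatter), shows only that the change from a small group to tert-butyl at this position lowered the number modestly. On that basis, a step of a 1.5-fold higher number from compound 2 to compound 3 (0.16 log units; within the scatter) is expected, the estimate for compound 3 in this assay being 9000 nM, within a range from 3000 nM to 30000 nM.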

Compound 3, half-maximal inhibitory concentration: 5100 nM
Compound 3: middle estimate off by 1.8-fold (0.25 log units), on the high side, within the range that was stated.
By their numbers in this assay, from the lowest: compounds 3 and 2 (each within the scatter of the next); then compound 1.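

In this assay, the step of a 1.2-fold lower number from compound 2 to compound 3 (0.08 log units; within the scatter) shows that, on this carbonyl carbon, the open 3-chloropropyl chain and the branched tert-butyl cannot be told apart, so branching is not needed to hold the number at this level. The step of a 4.1-fold lower number from compound 1 to compound 3 (0.61 log units; beyond the scatter) is of modest size and shows that a lower number than that of the methyl amide is not special to tert-butyl, as both four-heavy-atom groups shown at this place give it. Nothing available speaks to the reason for this result.

The compounds shown do not separate the part played by the chlorine from that of the chain, which a plain propyl group would address. From the compounds shown here alone, whether the number moves further with a longer chain, or with an amine or a carboxylic acid at the chain end, remains open.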